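The source may hold more compounds than are shown below. What is called first, only, known or untested is meant among the compounds shown, and "the series" means these compounds.

The series is followed in an ADME assay on HepG2 cells (Homo sapiens) for cytotoxicity, read by CellTiter-Glo and ATP content, with a stated time of 72 h; a higher number here means that more compound is needed for the effect, a lower number that less compound is needed. Compound 1 `CS(=O)(=O)c1ccc(C(=O)N2CCC(C(=O)N3CCc4ccccc43)CC2)cc1[N+](=O)[O-]` gives in this assay > 27000 nM, which is a limit of the assay rather than a number. Compound 2 `CC1CCN(C(=O)CCCNC(=O)c2ccc(S(C)(=O)=O)c([N+](=O)[O-])c2)CC1` likewise returns only a limit in this assay, > 27000 nM. Within the data shown here, both known values sit together at the limit of > 27000 nM in this assay, at which 2 of the 2 values shown sit, so no step between measured compounds can be read from the series, and no ordering of the two compounds follows. Compound 3 `CC(C)N(C(=O)C1CCN(C(=O)c2ccc(S(C)(=O)=O)c([N+](=O)[O-])c2)CC1)C(C)C` has not yet been measured in this assay; it differs from compound 1 by diisopropylamino in place of 2,3-dihydro-1H-indol-1-yl on a carbonyl carbon, in words diisopropylamino in place of 2,3-dihydro-1H-indol-1-yl on a carbonyl carbon. Among the measured compounds shown here, with every measured value at the limit and no measured step to lean on, the step is expected to be a step that the limit leaves unreadable from compound 1 to compound 3, none beyond the scatter. The value for compound 3 in this assay is accordingly estimated at 30000 nM, within a range from 12000 nM to 80000 nM, most probably returned again only as a limit.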

Compound 3, half-maximal effective concentration: > 27000 nM
Compound 3 ended at the assay's limit; the forecaster's own chance of this, stated with the estimate: 80%; the middle value lies beyond the limit too.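

In this assay compound 3 gives > 27000 nM, a limit and not a number. Compound 1 also stands at a limit, so no step can be read between compound 1 and compound 3: the limit of > 27000 nM in this assay, at which 3 of the 3 values shown sit.

The compounds shown leave open whether diisopropylamino and 2,3-dihydro-1H-indol-1-yl differ at all in this assay.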